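Benzyl to methyl on the amide nitrogen of the shared core

This account rests on a few compounds, and the source may have more. Where it says the series, first, only, none or still open, it means among the compounds named here.

Three compounds of the series have numbers in an assay for inhibition of Rho-associated protein kinase 1 (Homo sapiens), read by TR-FRET, with stated times of 5 min and 2 h; a lower number here means a stronger inhibitor, a higher number a weaker inhibitor. Compound 1 `CC1(C)NC(=O)c2cc(-c3ccncc3)sc2N1` gives 100 nM in this assay. Compound 3 `CN1c2cc(-c3cn[nH]c3)sc2C(=O)NC1(C)C` gives 130 nM in this assay. Compound 2 `CC1(C)Nc2cc(-c3ccncc3)sc2C(=O)N1Cc1ccccc1` gives 1.5 nM in this assay and stands lowest of the three, beyond the scatter below both compound 1 and compound 3. Its nearest neighbour on the numbers is compound 1 and its furthest is compound 3, the two of which stand within the scatter of each other.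

The next compound, compound 4 `CN1C(=O)c2sc(-c3ccncc3)cc2NC1(C)C`, has not yet been measured in this assay. It differs from compound 2 in one place: hydrogen in place of phenyl on a saturated chain carbon bound to an amide-type nitrogen in a ring. Among the measured compounds shown here, no step between measured compounds isolates this change. What the measured compounds show is that the two compounds without the benzyl group, compound 1 and compound 3, both lie well above compound 2 in this assay.

On that basis a step upward, beyond the scatter, is expected from compound 2 to compound 4, with the number for compound 4 settling nearer to those of compound 1 and compound 3 than to that of compound 2, that is a 40-fold higher number from compound 2 to compound 4 (1.60 log units; beyond the scatter). Compound 4 is accordingly estimated at 60 nM in this assay, within a range from 15 nM to 250 nM.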

Compound 4, half-maximal inhibitory concentration: 240 nM
Estimate against measurement, compound 4: 4.0-fold (0.60 log units) below; measured number inside the range.
By their numbers in this assay, from the lowest: compound 2; then compounds 1, 3 and 4 (each within the scatter of the next, the first and the last beyond it).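

In this assay, hydrogen in place of phenyl on a saturated chain carbon bound to an amide-type nitrogen in a ring gives a 160-fold higher number from compound 2 to compound 4 (2.20 log units; beyond the scatter) and is the only step shown that isolates this change. Among the compounds shown here, with one place altered and the rest of the structure held, the low number of compound 2 is now tied directly to the benzyl group, a link that the earlier compounds, which offered no single-place step, could only suggest. The data on hand offer no explanation for the size of this step.

The compounds shown leave open whether the phenyl ring itself is what matters, or whether a cyclohexylmethyl group, a simple ethyl group or a longer chain such as phenethyl on the same amide-type nitrogen would hold a number close to that of compound 2. Also open, on these data alone, is how substituents on the phenyl ring, such as a fluorine, a methoxy group or an amine, would shift the number from that of compound 2.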